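Replacing the 2-fluorophenyl group of compound 3

The source may report more compounds than this note shows. Statements on the series, on what has been measured and on what is new or still open speak of the compounds shown alone.

- compound 1 `C#Cc1cccc(N2C(=O)CSC2c2cccc(C(=O)NCCCCc3ccccc3)c2)c1`: 149 nM
- compound 2 `COc1cccc(OC)c1N1C(=O)CSC1c1cccc(C(=O)NCCCCc2ccccc2)c1`: > 1000 nM (a limit)
- compound 3 `O=C(NCCCCc1ccccc1)c1cccc(C2SCC(=O)N2c2ccccc2F)c1`: 34.1 nM

In a functional assay on HOS-TE85 cells (Homo sapiens) for inhibition, read by CCK-8 assay, with a stated time of 72 h (a higher number here means a weaker inhibitor, a lower number a stronger inhibitor), compound 3 gives 34.1 nM, the lowest number of the three. Compound 4 `CC(F)(F)c1cccc(N2C(=O)CSC2c2cccc(C(=O)NCCCCc3ccccc3)c2)c1` differs from it on the amide-type nitrogen in a ring: a group of 10 heavy atoms (8 carbon, 2 fluorine; one six-membered aromatic ring of carbon only) in place of a group of 7 heavy atoms (6 carbon, 1 fluorine; one six-membered aromatic ring of carbon only), on an amide-type nitrogen in a ring. Changes in this same place have already moved the number, with a 4.4-fold lower number from compound 1 to compound 3 (0.64 log units; beyond the scatter) and an at least 29-fold lower number from compound 2 to compound 3 (1.46 log units; beyond the scatter). For compound 2 the value > 1000 nM is a limit. The better guide is compound 1 at 149 nM, which also lacks the 2-fluorophenyl and has a true number, so a modest step to a higher number is expected in this assay. The estimated change is a 3.5-fold higher number from compound 3 to compound 4 (0.55 log units; beyond the scatter). Compound 4 is expected at 120 nM, with an estimated range from 30 nM to 500 nM.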

Compound 4, half-maximal inhibitory concentration in the HOS-TE85 assay: 29.1 nM
Compound 4: the middle estimate sits 4.1-fold (0.62 log units) above what was measured; the measured number lies below the stated range.
By their numbers in the HOS-TE85 assay, from the lowest: compounds 4 and 3 (each within the scatter of the next); then compound 1. At a limit, above all of these: compound 2.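

Among these compounds, in the HOS-TE85 assay, a group of 10 heavy atoms on the amide-type nitrogen in a ring performs no differently from 2-fluorophenyl (a 1.2-fold lower number from compound 3 to compound 4 (0.07 log units; within the scatter)), so this position accepts more heavy atoms than the earlier compounds showed. The same comparison separates 1,1-difluoroethyl from ethynyl on an aromatic carbon (a 5.1-fold lower number from compound 1 to compound 4 (0.71 log units; beyond the scatter)) and the new group from the dimethoxy-bearing ring of equal heavy-atom count (an at least 34-fold lower number from compound 2 to compound 4 (1.53 log units; beyond the scatter)). In the HOS-TE85 assay compound 2 gives > 1000 nM, which is a limit, so its step gives only a bound: the limit of > 1000 nM in the HOS-TE85 assay, at which 1 of the 4 values shown sits.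

In a physicochemical assay for solubility, read by turbidimetry, measured as kinetic solubility, at pH 6.8 (on this read-out higher numbers stand for higher solubility and lower numbers for lower solubility), compound 3 gives 20000 nM and compound 4 gives 10000 nM. These two values lie within the usual scatter of each other.

Going by these compounds, whether an amine or a carboxylic acid in place of the 1,1-difluoroethyl keeps this level remains open. So does whether a longer fluorinated chain does.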